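This account rests on a few compounds, and the source may have more. Where it says the series, first, only, none or still open, it means among the compounds named here.

Compound 1 `COC(=O)[C@@]1(C)CCC=C2[C@@H]1CC[C@@H](C)[C@]2(C)Cc1c[nH]c2ccc(C)cc12` gives the highest number of the three measured in a functional assay on SW1573 cells (Homo sapiens) for inhibition, read by sulforhodamine B assay, with a stated time of 48 h; a higher number here means a weaker inhibitor of growth, a lower number a stronger inhibitor of growth: compound 1 gives 15000 nM. Compound 2 `COC(=O)[C@@]1(C)CCC=C2[C@@H]1CC[C@@H](C)[C@]2(C)Cc1c[nH]c2ccc(OC)cc12` gives 1300 nM and compound 3 `COC(=O)[C@@]1(C)CCC=C2[C@@H]1CC[C@@H](C)[C@]2(C)Cc1c[nH]c2ccc(C(F)(F)F)cc12` gives 14000 nM; the steps are a 12-fold lower number from compound 1 to compound 2 (1.06 log units; beyond the scatter) and a 1.1-fold lower number from compound 1 to compound 3 (0.03 log units; within the scatter). Compound 4 `COC(=O)[C@@]1(C)CCC=C2[C@@H]1CC[C@@H](C)[C@]2(C)Cc1c(C)[nH]c2ccc(C)cc12` differs from compound 1 by methyl in place of hydrogen on an aromatic carbon, placed on an aromatic carbon of a five-membered aromatic ring with 1 nitrogen, next to the ring nitrogen and next to the ring atom that bears a large group. Within the data shown here, no measured step exchanges hydrogen for methyl at this place; the two measured steps concern other groups, so none bears directly on this change. With nothing to anchor a shift, no step beyond the scatter is expected in this assay, the expected step being no change at the digits printed from compound 1 to compound 4 (within the scatter). Compound 4 is estimated at 15000 nM, between 5000 nM and 45000 nM.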

Compound 4, concentration for 50% growth inhibition: 18000 nM
Compound 4: the middle estimate sits 1.2-fold (0.08 log units) below what was measured; low and high end bracket the measured number.
By their numbers in this assay, from the lowest: compound 2; then compounds 3, 1 and 4 (each within the scatter of the next).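

In this assay, methyl in place of hydrogen on an aromatic carbon of the five-membered aromatic ring, next to the ring nitrogen, gives a 1.2-fold higher number from compound 1 to compound 4 (0.08 log units; within the scatter). Among these compounds, this position therefore takes a methyl on the core of compound 1 without a step beyond the scatter, whereas the earlier steps concerned only another aromatic carbon. No evidence bears on the reason for this result. From the compounds shown here alone, whether methyl here behaves the same way alongside the methoxy of compound 2 remains open. So does the outcome with a phenyl ring, an amine or a carboxylic acid at this place.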